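This account rests on a few compounds, and the source may have more. Where it says the series, first, only, none or still open, it means among the compounds named here.

Of the compounds shown here, three built on a shared core have been tested in a functional assay on MDA-MB-231 cells (Homo sapiens) for inhibition, read by MTT assay, with a stated time of 72 h; on this read-out higher numbers stand for weaker inhibition and lower numbers for stronger inhibition. Compound 1 `CC(C)(C)n1cc2c(n1)C(=O)CC1(CCN(C(=O)c3cc(-c4ccccc4)nc4ccccc34)CC1)O2` carries a phenyl group on the core. In this assay compound 1 gives > 10000 nM, which is a limit of the assay and not a number. Compound 2 `Cc1ccccc1-c1cc(C(=O)N2CCC3(CC2)CC(=O)c2nn(C(C)(C)C)cc2O3)c2ccccc2n1` bears a 2-methylphenyl group in the same place. In this assay compound 2 gives > 10000 nM, again a limit rather than a measured number, so compound 2 stands at the edge of the assay and nowhere within its readable range. Compound 3 `CC(C)(C)n1cc2c(n1)C(=O)CC1(CCN(C(=O)c3cc(-c4ccc(Br)cc4)nc4ccccc34)CC1)O2` carries a 4-bromophenyl group. In this assay compound 3 gives > 10000 nM, also a limit of the assay. All three values thus share (the limit of > 10000 nM in this assay, at which 3 of the 3 values shown sit). The three measured steps, a step that the two limits leave unreadable from compound 1 to compound 2, a step that the two limits leave unreadable from compound 1 to compound 3 and a step that the two limits leave unreadable from compound 2 to compound 3, therefore offer no readable size and no direction.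

Compound 4 `COc1ccc(-c2cc(C(=O)N3CCC4(CC3)CC(=O)c3nn(C(C)(C)C)cc3O4)c3ccccc3n2)cc1OC` differs from compound 2 by 3,4-dimethoxyphenyl in place of 2-methylphenyl on an aromatic carbon. For the measured compounds named here, none of the measured steps gives a size for a change on this aromatic carbon, and every measured compound sits at the limit. The step from compound 2 to compound 4 is consequently expected to be a step that the limit leaves unreadable from compound 2 to compound 4, most likely leaving compound 4 at the limit as well. Compound 4 is estimated at 15000 nM in this assay, with a range from 5000 nM to 50000 nM.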

Compound 4, half-maximal inhibitory concentration: 7130 nM
Compound 4: the middle estimate sits 2.1-fold (0.32 log units) above what was measured, within the range that was stated.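

At this aromatic carbon, next to the ring nitrogen, 3,4-dimethoxyphenyl is the only one of the four groups shown that gives a number rather than a limit in this assay. Set against the other three groups, the change reads as an at least 1.4-fold lower number from compound 2 to compound 4 (0.14 log units; that floor lies within the scatter) and as an at least 1.4-fold lower number from compound 3 to compound 4 (0.14 log units; that floor lies within the scatter) and as an at least 1.4-fold lower number from compound 1 to compound 4 (0.14 log units; that floor lies within the scatter). From the compounds shown here alone, each of these floors lies within the scatter, so the direction is suggested but the true size of the change stays unknown, the steps among compounds 1, 2 and 3 cannot be read, and most of the series remains at the edge of the read-out: the limit of > 10000 nM in this assay, at which 3 of the 4 values shown sit.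

The compounds shown leave open whether both methoxy groups are needed, or whether a phenyl carrying a single methoxy group, a hydroxy group or an amine would give a readable number at this carbon as well. They also leave open whether compound 4 would stay within the readable range if the tert-butyl group on the shared core gave way to a longer chain or a carboxylic acid.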